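Compound 3 to compound 4: methyl for trifluoromethyl

The source may hold more compounds than are shown below. What is called first, only, known or untested is meant among the compounds shown, and "the series" means these compounds.

Half-life values measured in an in vitro ADME assay on microsomes from liver (Simiiformes) (a higher number here means that the compound lasts longer, a lower number that the compound disappears faster), are these
compound 1 `CCOCc1cc(CCCOc2c(C)cc(-c3noc(C(F)(F)F)n3)cc2C)on1` gives > 2.5 h as a limit
compound 2 `Cc1ccc(CCCOc2c(C)cc(-c3noc(C(F)(F)F)n3)cc2C)cn1` gives 1.97 h
compound 3 `Cc1cc(-c2noc(C(F)(F)F)n2)cc(C)c1OCCCc1cccc(F)n1` gives > 2.5 h as a limit

Compound 3 stands at the limit of > 2.5 h in this assay, at which 2 of the 3 values shown sit, and has no exact number. Compound 4 `Cc1nc(-c2cc(C)c(OCCCc3cccc(F)n3)c(C)c2)no1` differs from it by methyl in place of trifluoromethyl on an aromatic carbon, which turns 5-(trifluoromethyl)-1,2,4-oxadiazol-3-yl into 5-methyl-1,2,4-oxadiazol-3-yl.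

For the measured compounds named here, no measured step touches this place. The steps on the saturated chain carbon bear on it only loosely. Two of them have floors within the scatter (an at least 1.2-fold lower number from compound 1 to compound 2 (0.10 log units; that floor lies within the scatter)) and (an at least 1.2-fold higher number from compound 2 to compound 3 (0.10 log units; that floor lies within the scatter)), and the third cannot be read (a step that the two limits leave unreadable from compound 1 to compound 3). All three measured compounds keep trifluoromethyl, and compound 4 alone lacks it, which leaves the series without a direct precedent for this change. Going by the values given here, the only exact number belongs to compound 2 at 1.97 h and the expectation for compound 4 is placed under it. A drop beyond the scatter is expected in this assay (an at least 3.1-fold lower number from compound 3 to compound 4 (0.49 log units; beyond the scatter)), with its size loosely known. For compound 4 the estimated half-life is 0.8 h, with an expected range of 0.25 h to 2 h.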

Compound 4, half-life: 0.283 h
For compound 4 the middle estimate is 2.8-fold (0.45 log units) above the measured one, within the range that was stated.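

In this assay, methyl in place of trifluoromethyl on an aromatic carbon, with the 6-fluoropyridin-2-yl end of the molecule unchanged, gives an at least 8.8-fold lower number from compound 3 to compound 4 (0.94 log units; beyond the scatter) as the only step shown at this place. The half-life therefore responds clearly to the group on the five-membered aromatic ring, whereas the readable steps on the saturated chain carbon have floors that stay within the scatter, so this position is the only one shown with a change beyond it. The size of the step remains a floor and the full drop may be larger, because compound 3 has no exact number and stands at a limit: the limit of > 2.5 h in this assay, at which 2 of the 4 values shown sit.

A single pair cannot separate what methyl brings from what the loss of trifluoromethyl takes away, and difluoromethyl, ethyl, cyclopropyl or an amine at this place would show whether the half-life follows the fluorine atoms or the size of the group. From the compounds shown here alone, it also remains open whether the same change carries over to the 6-methylpyridin-3-yl or 3-(ethoxymethyl)-1,2-oxazol-5-yl end groups, where the shared core is otherwise the same.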